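Trifluoromethyl for Methoxy on Two Ligase Inhibitors at the Limit

The source may report more compounds than this note shows. Statements on the series, on what has been measured and on what is new or still open speak of the compounds shown alone.

Compound 1, `O=C1N[C@H]2[C@H](CS[C@H]2CCCCCc2cn(Cc3cccc(O)c3)nn2)N1`: in an assay on isolated protein for inhibition of biotin--protein ligase (Homo sapiens), read by scintillation counting, with a stated time of 10 min (a lower number here means a stronger inhibitor, a higher number a weaker inhibitor), compound 1 reaches only the assay limit > 16000 nM.
Compound 2, `COc1cccc(Cn2cc(CCCCC[C@@H]3SC[C@@H]4NC(=O)N[C@@H]43)nn2)c1`: in this assay compound 2 reaches only the assay limit > 16000 nM.

Compound 2 thus stands at the limit of this assay, not at a measured number. For the measured compounds named here, the only measured step, a step that the two limits leave unreadable from compound 1 to compound 2, cannot be read, since both ends sit at that limit, as the limit of > 16000 nM in this assay, at which 2 of the 2 values shown sit, shows. Compound 3, `O=C1N[C@H]2[C@H](CS[C@H]2CCCCCc2cn(Cc3cccc(C(F)(F)F)c3)nn2)N1`, differs from compound 2 by trifluoromethyl in place of methoxy on an aromatic carbon. Going by the values given here, no measured step speaks directly to this change; the one step available is unreadable, so no direction can be drawn from it. The expectation is that compound 3 also stays at the limit, and the step that the limit leaves unreadable from compound 2 to compound 3 is expected to be none beyond the scatter. Compound 3 is therefore estimated at 25000 nM, between 6000 nM and 100000 nM.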

Compound 3, inhibition constant: > 16000 nM
Compound 3: a limit, no number; the forecaster's own chance of this, stated with the estimate: 85%; the middle value does not contradict the limit.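

No step can be read among compound 1, compound 2 and compound 3, as each gives only a limit and not a number: the limit of > 16000 nM in this assay, at which 3 of the 3 values shown sit. The compounds shown leave open how hydroxy, methoxy and trifluoromethyl compare with one another in this assay.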